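Bis-benzylidene piperidinone sulfonamides: methyl step on the sulfonyl aryl

The source may hold more compounds than are shown below. What is called first, only, known or untested is meant among the compounds shown, and "the series" means these compounds.

Measured compounds:
Compound 1, `O=C1/C(=C/c2cccc(F)c2)CN(S(=O)(=O)c2ccccc2)C/C1=C\c1cccc(F)c1`: 12900 nM
Compound 2, `Cc1ccc(S(=O)(=O)N2C/C(=C\c3cccc(F)c3)C(=O)/C(=C/c3cccc(F)c3)C2)cc1`: 18100 nM
Compound 3, `O=C1/C(=C/c2ccc(F)cc2)CN(S(=O)(=O)c2ccccc2)C/C1=C\c1ccc(F)cc1`: 9100 nM

The series was tested in a functional assay on SMMC-7721 cells (Homo sapiens) for cytotoxicity, read by MTT assay, with a stated time of 24 h; on this read-out lower numbers stand for stronger inhibition and higher numbers for weaker inhibition. Compound 1 and compound 2 share a core and differ by methyl in place of hydrogen on an aromatic carbon; this gave a 1.4-fold higher number from compound 1 to compound 2 (0.15 log units; within the scatter). Compound 3 carries its fluorines elsewhere than compound 1; how the two cores differ is not broken down here. In this assay compound 3 gives 9100 nM, which lies within the scatter of compound 1 and compound 2.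

Compound 4, `Cc1ccc(S(=O)(=O)N2C/C(=C\c3ccc(F)cc3)C(=O)/C(=C/c3ccc(F)cc3)C2)cc1`, has not yet been measured. It differs from compound 3 by methyl in place of hydrogen on an aromatic carbon. Within the data shown here, this is the same change as the one from compound 1 to compound 2, and the place is described in the same words for both pairs.

Among the measured compounds shown here, the step from compound 3 to compound 4 is expected to be a 1.4-fold higher number from compound 3 to compound 4 (0.14 log units; within the scatter), resting on the single measured precedent a 1.4-fold higher number from compound 1 to compound 2 (0.15 log units; within the scatter), which stayed within the scatter. Compound 4 is therefore estimated at 12500 nM in this assay, with a plausible range from 6000 nM to 26000 nM.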

Compound 4, half-maximal inhibitory concentration: 5000 nM
Compound 4: the middle estimate sits 2.5-fold (0.40 log units) above what was measured, outside the stated range (below it).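

In this assay, the change from phenylsulfonyl to (4-methylphenyl)sulfonyl on the core carrying compound 3 gave a 1.8-fold lower number from compound 3 to compound 4 (0.26 log units; within the scatter). Set beside the same change on the core of compound 1, the two steps cannot be told apart: the same change on two cores in this assay, a 1.4-fold higher number (0.15 log units; within the scatter) from compound 1 to compound 2 and a 1.8-fold lower number (0.26 log units; within the scatter) from compound 3 to compound 4, 2.6-fold (0.41 log units) apart, within the scatter of two such steps. Across these two pairs, the methyl step stays within the scatter on both cores, so carrying it from one core to the other is consistent with the data, but two small steps do not establish a shared size or direction, nor do they show that the core has any influence on the step.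

The compounds shown leave open whether a group other than methyl at the same place, such as an amine, a carboxylic acid or a longer chain, would give a step beyond the scatter. They also leave open whether the methyl step would hold on cores with other substituents in place of the fluorines, such as chlorine or methoxy.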